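The source may hold more compounds than are shown below. What is called first, only, known or untested is meant among the compounds shown, and "the series" means these compounds.

In a functional assay on L1210 cells (Mus musculus) for cytotoxicity, read by MTT assay, with a stated time of 24 h (on this read-out higher numbers stand for weaker inhibition and lower numbers for stronger inhibition), compound 1 (`COc1cc(C(=O)/C=C/c2ccc(Cl)c(Cl)c2)cc(OC)c1OC`) gives 44000 nM and compound 2 (`COc1cc(C(=O)/C=C/c2ccc(Cl)cc2)cc(OC)c1OC`) gives 44500 nM with the two level within the scatter. Compound 3 (`COc1cc(C(=O)/C=C/c2ccc(C)cc2)cc(OC)c1OC`) carries methyl in place of chloro on an aromatic carbon of compound 2 (methyl in place of chloro on an aromatic carbon). Going by the values given here, the only measured step, a 1.0-fold higher number from compound 1 to compound 2 (0.00 log units; within the scatter) for hydrogen in place of chloro on an aromatic carbon, stayed within the scatter, but no measured step replaces this chloro itself. No step beyond the scatter is therefore expected in this assay for this change. Compound 3 is expected at 40000 nM (estimated range 18000 nM to 90000 nM). The estimated step is a 1.1-fold lower number from compound 2 to compound 3 (0.05 log units; within the scatter) and is expected to stay within the scatter.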

Compound 3, half-maximal inhibitory concentration: 50500 nM
The estimate for compound 3 lay 1.3-fold (0.10 log units) below the measured number, within the range that was stated.
By their numbers in this assay, from the lowest: compounds 1, 2 and 3 (each within the scatter of the next).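

In this assay, going by these compounds alone, the swap of chloro for methyl, para to a large group, gives a 1.1-fold higher number from compound 2 to compound 3 (0.05 log units; within the scatter) and is the first measured step that replaces this chloro itself. Going from 3,4-dichlorophenyl to 4-methylphenyl gives a 1.1-fold higher number from compound 1 to compound 3 (0.06 log units; within the scatter) and likewise leaves the numbers level, so neither change separates these compounds here. Nothing available explains this level result. From the compounds shown here alone, whether an amine or a carboxylic acid at this position would give a step beyond the scatter stays open.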